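Plasma half-life: methyl in place of ethoxycarbonyl

The compounds below may be only part of what the source reports. "The series", "measured", "known", "first", "only" and "open" are said of these compounds alone.

Compound 1 `CCCC(CCC)C(=O)N(C)/N=N/c1ccc(C(=O)OCC)cc1` carries an ethoxycarbonyl on an aromatic carbon of the shared core. In an ADME assay on a cell-free system (plasma, Homo sapiens) for metabolic stability, read by HPLC (on this read-out higher numbers stand for a longer-lived compound and lower numbers for a shorter-lived compound), compound 1 gives > 40 h, which is a limit of the assay and not a number. Compound 2 `CCCC(CCC)C(=O)N(C)/N=N/c1ccc(C(N)=O)cc1` gives > 40 h, again a limit. Compound 3 `CCCC(CCC)C(=O)N(C)/N=N/c1ccc(Br)cc1` gives > 40 h, also a limit. Among the compounds with values here, all three values therefore sit at the limit of > 40 h in this assay, at which 3 of the 3 values shown sit, and none of the measured steps can be read in size: a step that the two limits leave unreadable from compound 1 to compound 2, a step that the two limits leave unreadable from compound 1 to compound 3 and a step that the two limits leave unreadable from compound 2 to compound 3 are all unreadable. Compound 1 thus stands only at a limit, with no number to place it against the others.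

Compound 4 `CCCC(CCC)C(=O)N(C)/N=N/c1ccc(C)cc1` differs from compound 1 as follows: methyl in place of ethoxycarbonyl on an aromatic carbon. The closest measured comparison is the step in which ethoxycarbonyl on an aromatic carbon also leaves, a step that the two limits leave unreadable from compound 1 to compound 3, but its size cannot be read. Within the data shown here, no measured compound shows a half-life that falls short of the limit after a change on that aromatic carbon, so no step beyond the scatter is expected in this assay. The estimate therefore means a step that the limit leaves unreadable from compound 1 to compound 4. For compound 4 the estimated half-life is 45 h, with a range from 20 h to 100 h, and a reading at the limit is the likeliest outcome.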

Compound 4, half-life: > 40 h
Compound 4: a limit, no number; the forecaster's own chance of this, stated with the estimate: 80%; the middle value lies beyond the limit too.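

In this assay, compound 4 stands at a limit, like compound 1, compound 2 and compound 3, so no step among these four compounds can be read: the limit of > 40 h in this assay, at which 4 of the 4 values shown sit.

The compounds shown leave open how the four half-lives rank and whether any group on that aromatic carbon would bring a half-life within the readable range.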